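Dropping the pyridinyl group from a weak salicylanilide

The compounds below may be only part of what the source reports. "The series", "measured", "known", "first", "only" and "open" are said of these compounds alone.

Measured so far:
compound 1 `N#Cc1ccc(NC(=O)c2cc(-c3cccnc3)ccc2O)cc1` — 8330 nM
compound 2 `CN(C(=O)c1cc(F)ccc1O)c1ccc(C#N)cc1` — > 10000 nM

Within the data shown here, compound 1 `N#Cc1ccc(NC(=O)c2cc(-c3cccnc3)ccc2O)cc1` is the only compound here with a numerical result. In a functional assay on KG-1 cells (Homo sapiens) for cytotoxicity, read by luminescence and CellTiter-Glo, with a stated time of 3 days (a higher number here means a weaker inhibitor, a lower number a stronger inhibitor), compound 1 gives 8330 nM. Compound 2 `CN(C(=O)c1cc(F)ccc1O)c1ccc(C#N)cc1` gives > 10000 nM in this assay, which is a limit of the assay and not a number, so it sits at the limit of > 10000 nM in this assay, at which 1 of the 2 values shown sits. Among the measured compounds shown here, the two compounds differ in more than one place, so no single step between them can be drawn.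

Compound 3 `N#Cc1ccc(NC(=O)c2ccccc2O)cc1` is not yet measured. It differs from compound 1 by hydrogen in place of pyridin-3-yl on an aromatic carbon. The change removes a whole ring from a compound that is already weak, and the expectation is a step beyond the usual scatter toward weaker inhibition, with a real chance that this assay reports only a limit. The estimated step from compound 1 to compound 3 is a 1.9-fold higher number from compound 1 to compound 3 (0.28 log units; within the scatter). Compound 3 is therefore expected at 16000 nM, within 5000 nM to 50000 nM.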

Compound 3, half-maximal inhibitory concentration: 5370 nM
Beside the measured number, compound 3's estimate is 3.0-fold (0.47 log units) above it, within the range that was stated.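

In this assay, putting hydrogen in place of pyridin-3-yl on the aromatic carbon para to a hydroxy group gives a 1.6-fold lower number from compound 1 to compound 3 (0.19 log units; within the scatter), so a whole ring leaves this position with no change that can be told from the scatter. Compound 1 alone could not show whether pyridin-3-yl contributed to its weak result, whereas this pair shows that the ring is not needed for the activity that remains in this cell assay. Nothing shown here gives a cause for this step.

From the compounds shown here alone, only pyridin-3-yl and hydrogen can be compared at this position, so it remains open whether a different group there, such as an amine or a carboxylic acid, would move the number beyond the scatter. Compound 2 differs from compound 3 in more than one place and offers no single-change comparison.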